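A Shorter Aldehyde Chain on the Shared Core

This account rests on a few compounds, and the source may have more. Where it says the series, first, only, none or still open, it means among the compounds named here.

Measured compounds:
compound 1, `COc1cccc(Sc2c(NS(=O)(=O)c3ccc(C(C)(C)C)cc3)noc2CCCCC=O)c1`: 1400 nM
compound 2, `COc1cccc(Sc2c(NS(=O)(=O)c3ccc(C(C)(C)C)cc3)noc2C)c1`: 530 nM

Among the compounds with values here, in an assay on A7R5 cells for displacement of a labelled ligand from Endothelin-1 receptor (Rattus norvegicus) (a lower number here means a stronger inhibitor, a higher number a weaker inhibitor), compound 2 gives 530 nM, the lowest of the two numbers; its only neighbour is compound 1, which in this assay gives 1400 nM. Compound 3, `COc1cccc(Sc2c(NS(=O)(=O)c3ccc(C(C)(C)C)cc3)noc2CCC=O)c1`, has not yet been measured. It differs from compound 2 by formylmethyl in place of hydrogen on a saturated chain carbon bound to an aromatic carbon. Within the data shown here, one step bears on this change: a 2.6-fold lower number from compound 1 to compound 2 (0.42 log units; beyond the scatter), where a longer aldehyde-bearing chain was removed from the same place. Compound 3 puts back a chain of that kind, but shorter, so a move back toward the number of compound 1 is expected, probably smaller than the step that removed the longer chain. The expected step is modest and upward: a 1.7-fold higher number from compound 2 to compound 3 (0.23 log units; within the scatter). Compound 3 is therefore expected to give about 900 nM, within a range from 400 nM to 2000 nM.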

Compound 3, half-maximal inhibitory concentration: 380 nM
For compound 3 the middle estimate is 2.4-fold (0.37 log units) above the measured one; the whole stated range lies above it.
By their numbers in this assay, from the lowest: compounds 3 and 2 (each within the scatter of the next); then compound 1.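

In this assay, placing formylmethyl on this saturated chain carbon gives a 1.4-fold lower number from compound 2 to compound 3 (0.14 log units; within the scatter), so compound 2 and compound 3 cannot be told apart and an aldehyde-bearing chain of this shorter length can stand here without a clear loss. Chain length does show up among these aldehydes, with a 3.7-fold lower number from compound 1 to compound 3 (0.57 log units; beyond the scatter), which ties the weaker number of compound 1 to its longer chain rather than to the presence of an aldehyde alone. No available evidence explains why the length of the chain matters at this position.

As far as these compounds go, it remains open whether the aldehyde contributes anything itself, which a plain propyl chain or a carboxylic acid at the chain end would help to show. The chain length at which the number begins to rise, somewhere between those of compound 3 and compound 1, is also unsettled.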